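Trading a Cyclopropyl for Hydrogen on the Amide Nitrogen

A few compounds are considered here, and "the series" means these few. Any claim that something is new, unique, unknown or untested is made for them only; others in the source may bear on it.

Three compounds sharing a fused bicyclic core with an unsaturated amide side chain have been tested in a functional assay on the whole organism with Mus musculus as the target, in the rotarod test; a lower number here means that less compound is needed, a higher number that more compound is needed for the effect. Compound 1 `O=C(/C=C1\CCc2c(F)ccc(F)c21)NC1CC1` gives 2 mg/kg in this assay, the lowest of the two readable numbers. Compound 2 `O=C(/C=C1\CCc2cc(F)ccc21)NC1CC1` gives 193 mg/kg in this assay, a much higher number than compound 1, with a gap well beyond the usual scatter. How the cores of compound 1 and compound 2 differ is not broken down here.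

Compound 3 `NC(=O)/C=C1\CCc2cc(F)ccc21` reaches only a limit of this assay, > 100 mg/kg, and not a number. The change from compound 2 to compound 3 is hydrogen in place of cyclopropyl on an amide-type nitrogen. Its step, a step that the limit leaves unreadable from compound 2 to compound 3, cannot be given a size because compound 3 sits at the limit of > 100 mg/kg in this assay, at which 1 of the 3 values shown sits.

Compound 4 `NC(=O)/C=C1\CCc2c(F)ccc(F)c21` has not yet been measured. Within the data shown here, it differs from compound 1 by hydrogen in place of cyclopropyl on an amide-type nitrogen, which is the same change at the same place as the one from compound 2 to compound 3. Among the measured compounds shown here, the step from compound 1 to compound 4 is expected to be a 10-fold higher number from compound 1 to compound 4 (1.00 log units; beyond the scatter), an expectation resting on compound 2 with 193 mg/kg and on compound 3 at the limit of > 100 mg/kg in this assay, at which 1 of the 3 values shown sits, which together show only that the change did not bring the number far down and leave its size open. Compound 4 is therefore estimated at 20 mg/kg, with a range from 3 mg/kg to 150 mg/kg.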

Compound 4, dose for half-maximal effect: 89 mg/kg
The estimate for compound 4 lay 4.5-fold (0.65 log units) below the measured number; the range from low to high includes it.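

In this assay, replacing the cyclopropyl on the amide-type nitrogen of compound 1 with hydrogen gives a 45-fold higher number from compound 1 to compound 4 (1.65 log units; beyond the scatter), so on this core much more compound is needed for the effect once the ring is gone. This gives the change a readable size on one core only, and no size can be set beside it for the core of compound 2. The matching step cannot be read, since compound 3 stands at a limit and not a number: the limit of > 100 mg/kg in this assay, at which 1 of the 4 values shown sits.

On these data alone, whether the change is just as large on both cores therefore stays unknown, and the pair of compound 2 and compound 3 neither confirms nor contradicts that it carries over at this size. The compounds shown have only cyclopropyl or hydrogen on this nitrogen, so it also stays open whether the number depends on the ring itself or whether any small carbon group there would serve as well. A methyl, an isopropyl or a cyclobutyl on the same nitrogen would show how the number behaves between these two ends.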